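The compounds below may be only part of what the source reports. "The series", "measured", "known", "first", "only" and "open" are said of these compounds alone.

Compound 1, `COc1ccc(-c2nc(C)c(C(=O)CSc3nc(-c4ccc(Cl)cc4)c(C#N)c(=O)[nH]3)s2)cc1`: 102%
Compound 2, `COc1ccc(-c2nc(C)c(C(=O)CSc3nc(N)c(C#N)c(-c4ccc(OC)cc4)n3)s2)cc1`: 35.6%

Of the compounds shown here, two have been measured in a functional assay on U-87MG ATCC cells for antiproliferative activity against U-87 MG (Homo sapiens), read by MTT assay, with a stated time of 48 h, tested at 5 uM; a higher number here means a weaker effect of the compound at the concentration tested, a lower number a stronger effect. Compound 1 gives 102% and stands highest of the two numbers; compound 2 gives 35.6%, a gap beyond the scatter, so compound 2 shows the stronger effect of the pair. Going by the values given here, no step between measured compounds that differ in only one place is available.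

Compound 3, `COc1ccc(-c2nc(C)c(C(=O)CSc3nc(-c4ccc(Cl)c(Cl)c4)c(C#N)c(=O)[nH]3)s2)cc1`, differs from compound 1 by chloro in place of hydrogen on an aromatic carbon. Among the compounds with values here, nothing among the measured compounds tells how such a change acts on this core. The shared core of compound 1 and compound 3 sits at the weak end of the numbers shown, and a single added chloro is expected to move it little: the step of a number 9 percentage points lower from compound 1 to compound 3 (within the scatter) is expected to lie within the scatter, leaning if anything toward a slightly stronger effect. Compound 3 is therefore estimated at 93%, with a range from 70% to 106%.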

Compound 3, a percentage reported as activity, at one concentration (the size of the read-out at that concentration, not a potency): 101%
The estimate for compound 3 lay 8 percentage points below the measured number; low and high end bracket the measured number.
By their numbers in this assay, from the lowest: compound 2; then compounds 3 and 1 (each within the scatter of the next).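

Going by these compounds alone, the change from 4-chlorophenyl to 3,4-dichlorophenyl in this assay gives a number 1 percentage points lower from compound 1 to compound 3 (within the scatter) and is the first step read between measured compounds that differ in one place. It shows that chloro in place of hydrogen on this aromatic carbon, ortho to a chloro group and meta to a large group, makes no difference beyond the scatter on the shared core of compound 1 and compound 3. Nothing measured here offers a reason for this result.

Going by these compounds, whether a hydroxyl group or a carboxylic acid on this same aromatic carbon would separate from compound 1 remains open. On these data alone, it also remains open whether chloro at this place would behave the same way on any other core.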